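Replacing an isopropyl amide with a 2-fluorocyclopropyl amide

The source may hold more compounds than are shown below. What is called first, only, known or untested is meant among the compounds shown, and "the series" means these compounds.

Measured so far:
Compound 1, `CCC(=O)N1CC2CC(C1)N2`: 98%
Compound 2, `CC(C)C(=O)N1CC2CC(C1)N2`: 86%
Compound 3, `O=C(C1CC=CC1)N1CC2CC(C1)N2`: 93%

All three share one core and differ only in the group attached to the carbonyl carbon. In an assay on SH-EP1 cells for agonist activity at Neuronal acetylcholine receptor; alpha4/beta2 (Homo sapiens), read by FLIPR and calcium flux (on this read-out lower numbers stand for smaller maximal responses and higher numbers for larger maximal responses), compound 2 gives 86%, the lowest of the three numbers. Its nearest neighbour is compound 3 with 93%, a gap that lies within the scatter, so the two cannot be told apart. Among the compounds with values here, compound 1 stands furthest away at 98%; the step of a number 12 percentage points lower from compound 1 to compound 2 (beyond the scatter) is the only one-place change measured here.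

Compound 4, `O=C([C@H]1C[C@H]1F)N1CC2CC(C1)N2`, has not yet been measured. It differs from compound 2 in one place: 2-fluorocyclopropyl in place of isopropyl on a carbonyl carbon.

Within the data shown here, no measured step replaces an isopropyl with a ring, so the data bear only loosely on this change. Among the measured compounds shown here, the one step measured, a number 12 percentage points lower from compound 1 to compound 2 (beyond the scatter), was modest, and compound 3, the only measured compound that carries a ring on the carbonyl carbon, sits within the scatter of compound 2. Little movement is therefore expected in this assay. Compound 4 is estimated at 89%, with a range from 72% to 102%, meaning an expected step of a number 3 percentage points higher from compound 2 to compound 4 (within the scatter).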

Compound 4, largest response reached (Emax), in percent of the reference or control that the assay uses: 110%
For compound 4 the middle estimate is 21 percentage points below the measured one, and the stated range ends below it.
By their numbers in this assay, from the lowest: compounds 2, 3 and 1 (each within the scatter of the next, the first and the last beyond it); then compound 4.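

In this assay, within the data shown here, the group on the carbonyl carbon turns out to move the response upward as well as downward: the only earlier one-place step, a number 12 percentage points lower from compound 1 to compound 2 (beyond the scatter), went down, whereas this change gives a number 24 percentage points higher from compound 2 to compound 4 (beyond the scatter) and also a number 12 percentage points higher from compound 1 to compound 4 (beyond the scatter). A ring on the carbonyl carbon is not enough by itself to reach this level, as compound 3, which also carries a ring there, gives 93% while compound 4 gives 110% and thus stands clear of all three earlier compounds on the printed values. Nothing available explains why the 2-fluorocyclopropyl group behaves this way.

The compounds shown leave open whether the rise belongs to the three-membered ring, to the fluorine or to the particular arrangement at the two defined stereocentres, a question that a plain cyclopropyl group and the other stereoisomers of the 2-fluorocyclopropyl group would address. On these data alone, it also remains open how far the response follows other groups at this place, such as a tert-butyl group or a 2,2-difluorocyclopropyl group.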